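This account rests on a few compounds, and the source may have more. Where it says the series, first, only, none or still open, it means among the compounds named here.

Measured compounds:
- compound 1 `NCc1ccc(COc2nc(N)nc3nc[nH]c23)cc1`: 0.23 uM
- compound 2 `NCc1ccccc1COc1nc(N)nc2nc[nH]c12`: 80 uM

In an assay with Methylated-DNA--protein-cysteine methyltransferase (Homo sapiens) as the target, in the absence of a further agent (a higher number here means that more compound is needed for the effect, a lower number that less compound is needed), compound 1 gives 0.23 uM, the lowest of the two numbers recorded; compound 2 gives 80 uM, a gap far beyond the scatter. For the measured compounds named here, no pair differing in one place has been measured, so the size of a single change is not yet known here. Compound 3 `Cc1ccc(COc2nc(N)nc3nc[nH]c23)cc1` differs from compound 1 by hydrogen in place of amino on a saturated chain carbon bound to an aromatic carbon. For this step a small shift is expected, a 1.5-fold higher number from compound 1 to compound 3 (0.18 log units; within the scatter), not clearly beyond the scatter in either direction. Compound 3 is estimated at 0.35 uM, range 0.08 uM to 1.5 uM.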

Compound 3, concentration for half-maximal effect: 0.32 uM
For compound 3 the middle estimate is 1.1-fold (0.04 log units) above the measured one; low and high end bracket the measured number.
By their numbers in this assay, from the lowest: compounds 1 and 3 (each within the scatter of the next); then compound 2.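

In this assay the step reads a 1.4-fold higher number from compound 1 to compound 3 (0.14 log units; within the scatter) for aminomethyl to methyl, so this pair cannot be told apart. At this saturated chain carbon bound to an aromatic carbon, the amino group can therefore give way to hydrogen without a step beyond the scatter. No data on the cause of this outcome are at hand.

As far as these compounds go, whether hydroxymethyl or a carboxylic acid in place of aminomethyl stays in the same range remains open. So does the size of the aminomethyl to methyl step in the setting of compound 2.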